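A few compounds are considered here, and "the series" means these few. Any claim that something is new, unique, unknown or untested is made for them only; others in the source may bear on it.

The measurements so far, all in a functional assay on the whole organism with Rattus norvegicus as the target, at a dose of 100 mg/kg; on this read-out higher numbers stand for more inhibition at the one dose given (going by the name of the read-out) and lower numbers for less inhibition:
compound 1, `CC/N=C(\S)NCCCCCCn1nc(-c2ccccc2)ccc1=O`, gives -5.6%;
compound 2, `C/N=C(\S)NCCCCCn1nc(-c2ccccc2)ccc1=O`, gives 68.9%;
compound 3, `CC/N=C(/NC#N)NCCCn1nc(-c2ccccc2)ccc1=O`, gives 62.9%.

Compound 3 stands second highest of these three: a number 6 percentage points lower from compound 2 to compound 3 (within the scatter) keeps it within the scatter of its nearest neighbour, while its gap to compound 1 lies beyond the scatter. Compound 4, `C=CCNC(=S)NCCCCn1nc(-c2ccccc2)ccc1=O`, arises from compound 3 by a group of 8 heavy atoms (5 carbon, 2 nitrogen, 1 sulfur; no ring) in place of a group of 8 heavy atoms (4 carbon, 4 nitrogen; no ring), on a saturated chain carbon, three bonds along the chain from an aromatic nitrogen. For the measured compounds named here, two measured steps bear on this. The step of a number 74.5 percentage points higher from compound 1 to compound 2 (beyond the scatter) shows that altering the group on the chain can swing this assay strongly. The step of a number 6 percentage points lower from compound 2 to compound 3 (within the scatter), an exchange at the same place as the present change, stayed within the scatter. A step of about a number 2.9 percentage points lower from compound 3 to compound 4 (within the scatter) is therefore expected in this assay, not beyond the scatter. Compound 4 is estimated at 60%, within 35% to 85%.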

Compound 4, a percentage reported as inhibition, in the whole organism at one dose (the size of the read-out at that dose, not a potency): 27.1%
For compound 4 the middle estimate is 32.9 percentage points above the measured one, outside the stated range (below it).
By their numbers in this assay, from the lowest: compound 1; then compound 4; then compounds 3 and 2 (each within the scatter of the next).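

In this assay, an exchange at the place three bonds along the chain from an aromatic nitrogen can matter strongly: a number 35.8 percentage points lower from compound 3 to compound 4 (beyond the scatter) here, although the earlier exchange at this place stayed within the scatter. Compound 4 also stands apart from its two relatives in opposite directions, with a number 41.8 percentage points lower from compound 2 to compound 4 (beyond the scatter) and a number 32.7 percentage points higher from compound 1 to compound 4 (beyond the scatter) in this assay. No measurement at hand explains these gaps.

Chain length and end group change together across compound 1, compound 2 and compound 4, so their separate shares remain open. Also open, from the compounds shown here alone, is how an amine or a carboxylic acid at the chain end would fare.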